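The source may report more compounds than this note shows. Statements on the series, on what has been measured and on what is new or still open speak of the compounds shown alone.

Measured compounds in this set:

Compound 1 `C=C/C=C\[C@H](C)[C@H](OC(N)=O)[C@@H](C)[C@H](O)[C@@H](C)C/C(C)=C\[C@H](C)[C@@H](O)[C@@H](C)/C=C\CCc1ccc(Oc2ccccc2)cc1` gives 4000 nM in a functional assay on MCF7 cells (Homo sapiens) for cytotoxicity; on this read-out higher numbers stand for weaker inhibition and lower numbers for stronger inhibition.
Compound 2 `C=C/C=C\[C@H](C)[C@H](OC(N)=O)[C@@H](C)[C@H](O)[C@@H](C)C/C(C)=C\[C@H](C)[C@@H](O)[C@@H](C)/C=C\CCc1cccc(OC)c1` gives 330 nM in this assay.
Compound 3 `C=C/C=C\[C@H](C)[C@H](OC(N)=O)[C@@H](C)[C@H](O)[C@@H](C)C/C(C)=C\[C@H](C)[C@@H](O)[C@@H](C)/C=C\CCc1ccc(C)c(F)c1` gives 1000 nM in this assay.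

Compound 3 holds the second highest number of the three. For the measured compounds named here, its nearest neighbour is compound 2, reached by a 3.0-fold higher number from compound 2 to compound 3 (0.48 log units; beyond the scatter); compound 1 stands further off, its number higher than that of compound 3, though no single step links the two.

Compound 4 `C=C/C=C\[C@H](C)[C@H](OC(N)=O)[C@@H](C)[C@H](O)[C@@H](C)C/C(C)=C\[C@H](C)[C@@H](O)[C@@H](C)/C=C\CCc1cc(O)cc(O)c1` is not yet measured. It differs from compound 3 as follows: 3,5-dihydroxyphenyl in place of 3-fluoro-4-methylphenyl on a saturated chain carbon, two bonds along the chain from a double-bonded chain carbon. Going by the values given here, only one measured step touches the same place, a 3.0-fold higher number from compound 2 to compound 3 (0.48 log units; beyond the scatter), and it was modest. Nothing measured carries two hydroxyls on this ring, so the direction is open. The three aryl variants so far span a range from compound 2 to compound 1, and compound 4 is expected to land inside that span, near the middle, with a 1.2-fold higher number from compound 3 to compound 4 (0.08 log units; within the scatter) as the expected step. Compound 4 is thus estimated at 1200 nM, within 300 nM to 5000 nM.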

Compound 4, half-maximal inhibitory concentration: 160 nM
Estimate against measurement, compound 4: 7.5-fold (0.88 log units) above; measured number outside the range, below it.
By their numbers in this assay, from the lowest: compound 4; then compound 2; then compound 3; then compound 1.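

In this assay, the ring at the end of the chain accepts two hydroxyl groups: 3,5-dihydroxyphenyl in place of 3-fluoro-4-methylphenyl gives a 6.3-fold lower number from compound 3 to compound 4 (0.80 log units; beyond the scatter), and in place of 3-methoxyphenyl it gives a 2.1-fold lower number from compound 2 to compound 4 (0.31 log units; beyond the scatter). The earlier aryl variants, with no hydroxyl on the ring, did not show that a group with 2 hydrogen-bond donors on a saturated chain carbon, two bonds along the chain from a double-bonded chain carbon, can take the number down from both of those compounds. No measurement at hand accounts for this shift, and its cause stays unassigned.

The compounds shown leave open whether a single hydroxyl would do the same as the pair. Also open, going by these compounds, is whether an amine or a carboxylic acid on this ring, or a longer chain leading to the 3,5-dihydroxyphenyl group, would keep the lower number.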